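A few compounds are considered here, and "the series" means these few. Any claim that something is new, unique, unknown or untested is made for them only; others in the source may bear on it.

Compound 1, `CCCC(=O)c1c(O)c(Cl)c(O)c(Cl)c1O`, is the starting point of this account. In an ADME assay on the whole organism (strain S2) for cytotoxicity, with Drosophila as the target, read by WST assay (on this read-out lower numbers stand for higher toxicity in this test and higher numbers for lower toxicity in this test), compound 1 gives only a limit, > 100000 nM. Compound 1 thus stands at the limit of > 100000 nM in this assay, at which 2 of the 3 values shown sit. Compound 3, `CCCCCCc1c(O)c(Cl)c(OC)c(Cl)c1O`, likewise gives only a limit in this assay, > 100000 nM. Compound 2, `CCCCCC(=O)c1c(O)c(Br)c(OC)c(Br)c1O`, gives a number in this assay, 12900 nM, though it differs from compound 1 in more than one place. Compound 4, `CCCCCCCC(=O)c1c(O)c(Cl)c(O)c(Cl)c1O`, has not yet been measured; it differs from compound 1 by butyl in place of hydrogen on a saturated chain carbon, three bonds along the chain from a carbonyl carbon. Within the data shown here, no step between measured compounds is known, so the size of this change can only be guessed. The step is expected to be an at least 2.5-fold lower number from compound 1 to compound 4 (0.39 log units; beyond the scatter), in the direction of higher toxicity, but a limit again is quite possible. For compound 4 the expected value is 40000 nM, within 10000 nM to 100000 nM.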

Compound 4, half-maximal cytotoxic concentration: 88500 nM
Estimate against measurement, compound 4: 2.2-fold (0.34 log units) below; the measured number falls inside the stated range.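

Butyl in place of hydrogen on a saturated chain carbon, three bonds along the chain from a carbonyl carbon, gives an at least 1.1-fold lower number from compound 1 to compound 4 (0.05 log units; that floor lies within the scatter) in this assay. Among these compounds, this is the first one-place change seen here, and it yields a measured number where compound 1 gives only a limit. As far as these compounds go, the true size of the step stays unknown because that end of it is a limit: the limit of > 100000 nM in this assay, at which 2 of the 4 values shown sit.

From the compounds shown here alone, whether a longer chain at this place would lower the number further remains open. So does whether a terminal amine on the chain would do the same.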